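From quinolin-4-yl to quinolin-3-yl in compound 4

The source may hold more compounds than are shown below. What is called first, only, known or untested is meant among the compounds shown, and "the series" means these compounds.

Compound 1 `CC[C@H]1OC(=O)[C@H](C)[C@@H](O[C@H]2C[C@@](C)(OC)[C@@H](O)[C@H](C)O2)[C@H](C)[C@@H](O[C@@H]2O[C@H](C)C[C@H](N(C)C)[C@H]2OCCCNCc2ccnc3ccccc23)[C@](C)(O)C[C@@H](C)CN(C)[C@H](C)[C@@H](O)[C@]1(C)O`: > 10000 ug/mL (a limit)
Compound 2 `CC[C@H]1OC(=O)[C@H](C)[C@@H](O[C@H]2C[C@@](C)(OC)[C@@H](O)[C@H](C)O2)[C@H](C)[C@@H](O[C@@H]2O[C@H](C)C[C@H](N(C)C)[C@H]2OCCCNCc2cnc3ccccc3c2)[C@](C)(O)C[C@@H](C)CN(C)[C@H](C)[C@@H](O)[C@]1(C)O`: > 10000 ug/mL (a limit)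
Compound 3 `CC[C@H]1OC(=O)[C@H](C)[C@@H](O[C@H]2C[C@@](C)(OC)[C@@H](O)[C@H](C)O2)[C@H](C)[C@@H](O[C@@H]2O[C@H](C)C[C@H](N(C)C)[C@H]2OCCCN(C)Cc2ccnc3ccccc23)[C@](C)(O)C[C@@H](C)CN(C)[C@H](C)[C@@H](O)[C@]1(C)O`: > 10000 ug/mL (a limit)

All three entries come from a physicochemical assay for solubility, at pH 4 (on this read-out higher numbers stand for higher solubility and lower numbers for lower solubility), and are limits, not numbers. Compound 3 gives > 10000 ug/mL as a limit only. Every measured compound stands at the limit of > 10000 ug/mL in this assay, at which 3 of the 3 values shown sit, so they cannot be ranked.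

Compound 4 `CC[C@H]1OC(=O)[C@H](C)[C@@H](O[C@H]2C[C@@](C)(OC)[C@@H](O)[C@H](C)O2)[C@H](C)[C@@H](O[C@@H]2O[C@H](C)C[C@H](N(C)C)[C@H]2OCCCN(C)Cc2cnc3ccccc3c2)[C@](C)(O)C[C@@H](C)CN(C)[C@H](C)[C@@H](O)[C@]1(C)O` differs from compound 3 by one change, quinolin-3-yl in place of quinolin-4-yl on a saturated chain carbon bound to an amine nitrogen. The other measured change, methyl in place of hydrogen on an amine nitrogen, appears as a step that the two limits leave unreadable from compound 1 to compound 3 and offers no size to work with. The same quinoline swap, seen as a step that the two limits leave unreadable from compound 1 to compound 2, gives neither size nor direction, so no step beyond the scatter is expected in this assay and compound 4 is expected to be reported as a limit again. The estimated change is a step that the limit leaves unreadable from compound 3 to compound 4, and it is only a rough figure. For compound 4 the estimated value is 12000 ug/mL, with an expected range from 6000 ug/mL to 30000 ug/mL.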

Compound 4, solubility: > 10000 ug/mL
Compound 4 gave a limit, no number (the forecaster's own chance of this, stated with the estimate: 90%); the middle value is on the limit's open side.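

In this assay compound 4 gives > 10000 ug/mL, which is a limit, not a number. The steps to compound 4 from compound 2 and compound 3 cannot be read, because all four compounds sit at the same limit: the limit of > 10000 ug/mL in this assay, at which 4 of the 4 values shown sit.

The compounds shown leave open whether swapping quinolin-4-yl for quinolin-3-yl, or adding methyl on the amine nitrogen, changes this read-out at all.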